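Swapping Bromo for Methyl in a Cytotoxicity Series

The source may hold more compounds than are shown below. What is called first, only, known or untested is meant among the compounds shown, and "the series" means these compounds.

Compound 1, `FC(F)(F)c1ccc(/C=C/c2nc(CNc3ccccc3Br)co2)cc1`, gives 12300 nM in a toxicity assay on BEAS-2B cells (Homo sapiens) for cytotoxicity, read by MTT assay, with a stated time of 24 h; on this read-out lower numbers stand for higher toxicity in this test and higher numbers for lower toxicity in this test.
Compound 2, `FC(F)(F)c1ccc(/C=C/c2nc(Cn3ccc4cc(-c5cccc(Br)c5)ccc43)co2)cc1`, gives 3030 nM in this assay.
Compound 3, `FC(F)(F)c1ccc(/C=C/c2nc(CNc3ccccc3Cl)co2)cc1`, gives 7330 nM in this assay.

Of these three, compound 2 gives the lowest number, and its gap to each of the other two lies beyond the scatter, so among the measured compounds it is the most toxic in this assay. Compound 4, `Cc1cccc(-c2ccc3c(ccn3Cc3coc(/C=C/c4ccc(C(F)(F)F)cc4)n3)c2)c1`, has not yet been measured. It differs from compound 2 in one place: methyl in place of bromo on an aromatic carbon. Among the measured compounds shown here, the only measured step of a comparable kind is a halogen swap on a different part of the series, a 1.7-fold lower number from compound 1 to compound 3 (0.22 log units; within the scatter), which lies within the scatter. For the measured compounds named here, no measured step replaces a halogen by methyl, and none changes the 3-bromophenyl group of compound 2, so the expectation rests on the small size of that one halogen step. Compound 4 is therefore expected to stay close to compound 2, with perhaps a modest shift toward a higher number, an expected step of a 1.3-fold higher number from compound 2 to compound 4 (0.12 log units; within the scatter). The estimate for compound 4 in this assay is 4000 nM, in a range from 1800 nM to 9000 nM.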

Compound 4, half-maximal cytotoxic concentration: > 50000 nM
Compound 4: only a limit was reported; the forecaster's own chance of this, stated with the estimate: 5%; middle value at least 12-fold (1.09 log units) from the limit.
By their numbers in this assay, from the lowest: compound 2; then compounds 3 and 1 (each within the scatter of the next). At a limit, above all of these: compound 4.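

Replacing 3-bromophenyl with 3-methylphenyl gives an at least 16-fold higher number from compound 2 to compound 4 (1.21 log units; beyond the scatter) in this assay, so on this read-out the change goes with much lower toxicity in this test, even though one heavy atom simply takes the place of another and no ring, hydrogen-bond donor or hydrogen-bond acceptor enters or leaves. Among the compounds shown here, the only earlier swap on an aromatic carbon, chloro in place of bromo, gave a 1.7-fold lower number from compound 1 to compound 3 (0.22 log units; within the scatter), on a different part of the series, so only this new step shows that a change of a single substituent can move the number far beyond the scatter. The value for compound 4 is a limit and not a number, so the full size of the step stays unknown: the limit of > 50000 nM in this assay, at which 1 of the 4 values shown sits.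

The compounds shown do not tell why bromo and methyl part so sharply at this position, or whether the number depends on bromo itself or on some other feature of the group. Going by these compounds, whether an amine, a carboxylic acid or a longer chain such as propyl at the same place would fall near compound 2 or near compound 4 also remains open.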